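The source may hold more compounds than are shown below. What is called first, only, known or untested is meant among the compounds shown, and "the series" means these compounds.

Compound 3 `C[S+]([O-])c1cn([C@H]2C[C@H](O)[C@@H](CO)O2)c(=O)[nH]c1=O` stands at a limit of an ADME assay on L1210/0 cells (Mus musculus) for cytotoxicity, with a stated time of 48 h; a lower number here means a stronger inhibitor, a higher number a weaker inhibitor: in this assay compound 3 gives > 200000 nM. For the measured compounds named here, compound 1 `O=c1[nH]c(=O)n([C@H]2C[C@H](O)[C@@H](CO)O2)cc1[N+](=O)[O-]` is the only compound here with a number, and in this assay compound 1 gives 130 nM. Compound 2 `N#Cc1cn([C@H]2C[C@H](O)[C@@H](CO)O2)c(=O)[nH]c1=O` also sits at a limit, and in this assay compound 2 gives > 200000 nM. The measured steps are an at least 1500-fold higher number from compound 1 to compound 2 (3.18 log units; beyond the scatter) and an at least 1500-fold higher number from compound 1 to compound 3 (3.18 log units; beyond the scatter), while a step that the two limits leave unreadable from compound 2 to compound 3; two of the three values share (the limit of > 200000 nM in this assay, at which 2 of the 3 values shown sit). Compound 4 `CCCCCC#Cc1cn([C@H]2C[C@H](O)[C@@H](CO)O2)c(=O)[nH]c1=O` differs from compound 3 by a group of 7 heavy atoms (7 carbon; no ring) in place of a group of 3 heavy atoms (1 carbon, 1 oxygen, 1 sulfur; no ring), on an aromatic carbon. Going by the values given here, no measured step of readable size ends or starts at compound 3, so the exchange has no direct precedent. Compound 4 is therefore expected to stay weak, at about 100000 nM within 20000 nM to 300000 nM. That estimate means a step of an at least 2.0-fold lower number from compound 3 to compound 4 (0.30 log units; that floor lies within the scatter).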

Compound 4, half-maximal inhibitory concentration: > 200000 nM
Compound 4: no number, only a limit; the forecaster's own chance of this, stated with the estimate: 55%; middle value at least 2.0-fold (0.30 log units) away from the limit.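

In this assay, replacing nitro with hept-1-yn-1-yl gives an at least 1500-fold higher number from compound 1 to compound 4 (3.18 log units; beyond the scatter), so a group made only of carbon on this aromatic carbon also fails to keep the activity of compound 1. Nitro remains the only group shown here that gives a number rather than a limit, and the steps from compound 2 and compound 3 to compound 4 cannot be read. The results now gather at one assay limit: the limit of > 200000 nM in this assay, at which 3 of the 4 values shown sit.

From the compounds shown here alone, how far compound 2, compound 3 and compound 4 lie past that limit stays unknown. Going by these compounds, it also remains open whether an amine, bromine or the shorter ethynyl at this place would keep any of the activity of compound 1.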